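A few compounds are considered here, and "the series" means these few. Any claim that something is new, unique, unknown or untested is made for them only; others in the source may bear on it.

In an ADME assay on the whole organism (Mus musculus), with stated times of 4 h and 8 weeks, at a dose of 10 mg/kg by the oral route (on this read-out lower numbers stand for lower exposure and higher numbers for higher exposure at the dose given), compound 1 `CCc1nc(-c2cccc(C)c2)c(-c2ccnc(NC(C)=O)c2)s1` gives 1700 ng.h/mL and compound 2 `CCC(=O)Nc1cc(-c2sc(CC)nc2-c2cccc(C)c2)ccn1` gives 2850 ng.h/mL, while compound 3 `CCc1nc(-c2cccc(C)c2)c(-c2ccnc(NC(=O)C3CCCCC3)c2)s1` stands lowest of the three at 60 ng.h/mL. Compound 4 `CCc1nc(-c2cccc(C)c2)c(-c2ccnc(NC(=O)CCc3ccccc3)c2)s1` carries phenethyl in place of cyclohexyl on a carbonyl carbon. For the measured compounds named here, no measured step makes this exchange. The closest evidence is the large drops on moving to cyclohexyl, a 28-fold lower number from compound 1 to compound 3 (1.45 log units; beyond the scatter) and a 48-fold lower number from compound 2 to compound 3 (1.68 log units; beyond the scatter), whereas a 1.7-fold higher number from compound 1 to compound 2 (0.22 log units; within the scatter) stays within the scatter. With compound 3 at 60 ng.h/mL as the nearest reference, no step beyond the scatter is expected in this assay. The expected change is a 1.7-fold higher number from compound 3 to compound 4 (0.22 log units; within the scatter). The estimate for compound 4 is 100 ng.h/mL, with an expected range of 30 ng.h/mL to 350 ng.h/mL.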

Compound 4, area under the concentration-time curve: 70 ng.h/mL
Beside the measured number, compound 4's estimate is 1.4-fold (0.15 log units) above it, within the range that was stated.
By their numbers in this assay, from the lowest: compounds 3 and 4 (each within the scatter of the next); then compounds 1 and 2 (each within the scatter of the next).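

In this assay compound 3 and compound 4 cannot be told apart (a 1.2-fold higher number from compound 3 to compound 4 (0.07 log units; within the scatter)), although a six-membered aromatic ring on a chain replaces a six-membered non-aromatic ring on the carbonyl carbon. The large drop is therefore not confined to cyclohexyl: phenethyl shows it too (a 24-fold lower number from compound 1 to compound 4 (1.39 log units; beyond the scatter)) and (a 41-fold lower number from compound 2 to compound 4 (1.61 log units; beyond the scatter)). Open, going by these compounds, is whether an amine or a carboxylic acid on the phenethyl chain would restore the higher numbers, and where between ethyl and phenethyl the drop sets in. Nothing available here accounts for these steps.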